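The source may report more compounds than this note shows. Statements on the series, on what has been measured and on what is new or still open speak of the compounds shown alone.

Measured so far:
compound 1 `C[Se]/C(=N\C(=O)c1cccs1)NC(=O)c1cccs1`: 12500 nM
compound 2 `O=C(/N=C(/NC(=O)c1ccno1)[Se]Cc1ccccc1)c1ccno1`: > 100000 nM
compound 3 `O=C(/N=C(/NC(=O)c1cccs1)[Se]Cc1ccccc1)c1cccs1`: 81500 nM

In a functional assay on HepG2 cells (Homo sapiens) for cytotoxicity, read by MTT assay, with a stated time of 72 h (on this read-out lower numbers stand for higher toxicity in this test and higher numbers for lower toxicity in this test), compound 1 gives 12500 nM and compound 3 gives 81500 nM. Compound 2 is a separate case: in this assay compound 2 returns only a limit, > 100000 nM, and this is the limit of > 100000 nM in this assay, at which 1 of the 3 values shown sits. Compound 2 and compound 3 differ in their cores, and that difference between the two cores is not broken down here.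

Compound 3 and compound 1 share a core and differ in one place: hydrogen in place of phenyl on a saturated chain carbon bound to a selenium atom. On this change this assay moves by a 6.5-fold lower number from compound 3 to compound 1 (0.81 log units; beyond the scatter).

Compound 4 `C[Se]/C(=N\C(=O)c1ccno1)NC(=O)c1ccno1` has not yet been measured. It stands to compound 2 as compound 1 stands to compound 3: hydrogen in place of phenyl on a saturated chain carbon bound to a selenium atom. The place is the same in both pairs, so this is the same change, made on the core of compound 2 instead of the core of compound 3.

Within the data shown here, the step from compound 2 to compound 4 in this assay is expected to be an at least 2.5-fold lower number from compound 2 to compound 4 (0.39 log units; beyond the scatter), resting on the one measured example of the change, a 6.5-fold lower number from compound 3 to compound 1 (0.81 log units; beyond the scatter). Because the value of compound 2 is > 100000 nM, a limit rather than a number, the starting point of that step is not fixed, and the expectation for compound 4 is correspondingly wide. For compound 4 a value of about 40000 nM is estimated, expected to fall between 12000 nM and 110000 nM.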

Compound 4, concentration lethal to 50% of the cells: > 100000 nM
Compound 4: no number, only a limit; the forecaster's own chance of this, stated with the estimate: 35%; middle value at least 2.5-fold (0.39 log units) away from the limit.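

In this assay compound 4 gives > 100000 nM, which is a limit and not a number. Compound 2 also gives only a limit, so no step between compound 2 and compound 4 can be read: the limit of > 100000 nM in this assay, at which 2 of the 4 values shown sit.

The compounds shown leave open whether benzyl to methyl changes the read-out in this assay on the core of compound 2 in any way comparable to a 6.5-fold lower number from compound 3 to compound 1 (0.81 log units; beyond the scatter).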